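The source may hold more compounds than are shown below. What is called first, only, known or untested is meant among the compounds shown, and "the series" means these compounds.

Three compounds have been measured in an assay (Cricetulus griseus) for inhibition of aldehyde dehydrogenase, mitochondrial (Homo sapiens); a lower number here means a stronger inhibitor, a higher number a weaker inhibitor:

Compound 1 `O=c1c(-c2ccc(O)cc2)coc2cc(OCCCCCCCCCCCCO)ccc12`: 1700 nM
Compound 2 `CCCCC(Oc1ccc2c(=O)c(-c3ccc(O)cc3)coc2c1)C(=O)OCC`: 4500 nM
Compound 3 `CCCCCCC(Oc1ccc2c(=O)c(-c3ccc(O)cc3)coc2c1)C(=O)O`: 2000 nM

Compound 1 gives the lowest number of the three, but compound 3 sits within the usual scatter of it, so the two cannot be separated; only compound 2 stands clearly apart with its higher number. The three share the same core and differ in the side chain attached through the oxygen on the aromatic ring.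

The step under consideration leads from compound 1 to compound 4 `O=C(O)CCCCOc1ccc2c(=O)c(-c3ccc(O)cc3)coc2c1`, which has not yet been measured in this assay. The change is carboxy in place of 8-hydroxyoctyl on a saturated chain carbon, four bonds along the chain from an oxygen on an aromatic ring. Within the data shown here, no pair of measured compounds differing in only one place is available, so the size of this step has to be judged from the three values alone. Compound 3, which also carries a carboxy group on its chain, lies close to compound 1, while compound 2 with its ethyl ester is weaker. Compound 4 is therefore expected to remain in the same general region, with a modest weakening; the expected step is a 1.8-fold higher number from compound 1 to compound 4 (0.25 log units; within the scatter). For compound 4 the estimate in this assay is 3000 nM, with a likely range from 1000 nM to 9000 nM.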

Compound 4, half-maximal inhibitory concentration: 100 nM
The estimate for compound 4 lay 30-fold (1.48 log units) above the measured number; measured number outside the range, below it.
By their numbers in this assay, from the lowest: compound 4; then compounds 1 and 3 (each within the scatter of the next); then compound 2.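

In this assay, among these compounds, putting carboxy in place of 8-hydroxyoctyl on a saturated chain carbon, four bonds along the chain from an oxygen on an aromatic ring, gives a 17-fold lower number from compound 1 to compound 4 (1.23 log units; beyond the scatter), a large step where the earlier compounds offered no single-place comparison at all. This shows that the number is highly sensitive to what stands at this position, and that a much smaller group with a carboxy end gives a far stronger inhibitor than the long hydroxy-ended chain: the leaving group has 9 heavy atoms and the entering one 3, while each counts one hydrogen-bond donor and one hydrogen-bond acceptor. No measurement at hand bears on why the change has this effect.

The step changes chain length and end group together, so the compounds shown do not separate the share of each. A hydroxy group on the short chain of compound 4 would address this, as would a carboxy group at the end of the long chain of compound 1, while an ethyl ester or a primary amide on the short chain would test how much depends on the free carboxy group itself.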